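The source may hold more compounds than are shown below. What is called first, only, known or untested is meant among the compounds shown, and "the series" means these compounds.

Measured so far:
compound 1, `COCCSCC1CN(C)CCC1c1ccc(Cl)cc1`, in an assay on isolated protein for inhibition of Norepinephrine transporter (Rattus norvegicus), read by radioligand binding; on this read-out lower numbers stand for stronger inhibition and higher numbers for weaker inhibition: 6 nM
compound 2, `CC(=O)OCC[S+]([O-])CC1CN(C)CCC1c1ccc(Cl)cc1`, in this assay: 29 nM

Of these two numbers, compound 1 has the lower one; compound 2 sits a good way higher, a gap beyond the usual scatter of repeated measurements of this kind. Compound 3, `CNC(=O)C[S+]([O-])CC1CN(C)CCC1c1ccc(Cl)cc1`, has not yet been measured. It differs from compound 1 in one place: a group of 7 heavy atoms (3 carbon, 1 nitrogen, 2 oxygen, 1 sulfur; no ring) in place of a group of 5 heavy atoms (3 carbon, 1 oxygen, 1 sulfur; no ring), on a saturated chain carbon bound to a saturated ring carbon. Within the data shown here, no pair of measured compounds shows exactly this change, so its likely effect can only be judged from the two numbers in hand. In this assay compound 2 gives 29 nM, a clearly weaker result than compound 1. Because compound 2 gives 29 nM while compound 1 gives 6 nM, the replacement is expected to move the number upward, so that the expected step is a 5.8-fold higher number from compound 1 to compound 3 (0.77 log units; beyond the scatter), a step of moderate size. For compound 3 the expected value in this assay is 35 nM, within a range from 10 nM to 120 nM.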

Compound 3, inhibition constant: 86 nM
Compound 3: middle estimate off by 2.5-fold (0.39 log units), on the low side, and the stated range covers the measured number.
By their numbers in this assay, from the lowest: compound 1; then compound 2; then compound 3.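

In this assay, putting the new group in place of (2-methoxyethyl)sulfanyl, on a saturated chain carbon bound to a saturated ring carbon, gives a 14-fold higher number from compound 1 to compound 3 (1.16 log units; beyond the scatter), a large step beyond the usual scatter. The second comparison is narrower: compound 2 and compound 3 both carry the sulfoxide, and methylcarbamoyl in place of acetoxymethyl on a saturated chain carbon bound to a sulfur gives a 3.0-fold higher number from compound 2 to compound 3 (0.47 log units; beyond the scatter), a modest step that is also beyond the scatter, so the end of the chain alone changes the number in this assay. Nothing available explains either step.

The step from compound 1 changes the sulfur and the end of the chain together, so the compounds shown leave open how much of it belongs to each; a compound with methylcarbamoyl on a plain sulfanyl chain would separate the two. Also open, on these data alone, is how the number would respond to other chain ends on the sulfoxide, such as a carboxylic acid, an amine or a longer chain.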